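The source may report more compounds than this note shows. Statements on the series, on what has been measured and on what is new or still open speak of the compounds shown alone.

Measured in a functional assay on CCRF-CEM cells (Homo sapiens) for cytotoxicity; a lower number here means a stronger inhibitor, a higher number a weaker inhibitor:
- compound 1 `Nc1ncnc2c1ncn2[C@@H]1S[C@H](CO)[C@H]1CO`: > 100000 nM
- compound 2 `OC[C@H]1[C@H](n2cnc3c(O)ncnc32)S[C@@H]1CO`: > 100000 nM
- compound 3 `Nc1nc(O)c2ncn([C@@H]3S[C@H](CO)[C@H]3CO)c2n1`: > 100000 nM

Compound 2 stands only as a limit of > 100000 nM, not as a number. The entries for compound 1 and compound 3 are limits too, so the whole series sits at one ceiling: the limit of > 100000 nM in this assay, at which 3 of the 3 values shown sit.

Compound 4 `OC[C@H]1[C@H](CO)S[C@@H]1n1cnc2c(O)ncnc21` differs from compound 2 in configuration alone: the two compounds have the same atoms and bonds and differ only in configuration as drawn: 3 of 3 stereo elements differ (all stereocentres are inverted: mirror images); a stereocentre at a saturated ring carbon is drawn R in compound 2 and S in compound 4; a stereocentre at a saturated ring carbon is drawn S in compound 2 and R in compound 4; a stereocentre at a saturated ring carbon is drawn R in compound 2 and S in compound 4.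

Among the compounds with values here, two measured steps touch compound 2: a step that the two limits leave unreadable from compound 1 to compound 2 and a step that the two limits leave unreadable from compound 2 to compound 3. Both are substituent changes on an aromatic carbon, neither has a readable size, and neither involves configuration. Within the data shown here, no measured step inverts a stereocentre.

In this assay, no step beyond the scatter is expected, and no direction can be assigned. This expectation rests on compound 2 with its limit of > 100000 nM.

The estimated step is a number no higher from compound 2 to compound 4 (the limit leaves the size open). Compound 4 is expected to reach the same ceiling, with an estimated value of 100000 nM and an expected range from 30000 nM to 300000 nM.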

Compound 4, half-maximal inhibitory concentration: > 100000 nM
Compound 4 gave a limit, no number; the forecaster's own chance of this, stated with the estimate: 85%; the middle value lies on the limit itself.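

In this assay compound 4 gives > 100000 nM, a limit and not a number. The entry for compound 2 is also a limit, so no step can be read between these two mirror images. The compounds shown leave open whether configuration, or any substituent change, alters potency in this assay: the limit of > 100000 nM in this assay, at which 4 of the 4 values shown sit.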